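Swapping a basic amine for a hydroxyl at the ether tail

The compounds below may be only part of what the source reports. "The series", "measured", "known", "first", "only" and "open" are said of these compounds alone.

Measured compounds:
- Compound 1, `Cn1nc(-c2ccc(OC[C@H]3CC[C@@H](N)CC3)c(F)c2)c2cnc(N)nc21`: in an assay on tissue (PBMC cells) for antagonist activity at Toll-like receptor 9 (Homo sapiens) (a lower number here means a stronger inhibitor, a higher number a weaker inhibitor), compound 1 gives 2200 nM.
- Compound 2, `Cc1cc(-c2ccnc3[nH]ncc23)cnc1OCC12CCC(O)(CC1)CC2`: in this assay compound 2 reaches only the limit > 5000 nM, so no number is known for it.
- Compound 3, `Cc1cc(-c2ccnc3[nH]ncc23)cnc1OCC12CCC(N)(CC1)CC2`: in this assay compound 3 gives 1000 nM.

Compound 1 stands highest of the two numbers shown; its nearest neighbour is compound 3, whose number is lower, a gap that lies beyond the scatter. For the measured compounds named here, the single step between measured compounds runs from compound 2 to compound 3, an at least 5.0-fold lower number from compound 2 to compound 3 (0.69 log units; beyond the scatter). That step rests on (the limit of > 5000 nM in this assay, at which 1 of the 3 values shown sits), so its true size is not known, only that it is at least modest.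

Compound 4, `Cn1nc(-c2ccc(OCC34CCC(O)(CC3)CC4)c(F)c2)c2cnc(N)nc21`, has not been measured. It differs from compound 1 in one place: a group of 9 heavy atoms (8 carbon, 1 oxygen; 2 six-membered non-aromatic rings of carbon only) in place of a group of 7 heavy atoms (6 carbon, 1 nitrogen; one six-membered non-aromatic ring of carbon only), on a saturated chain carbon bound to an oxygen on an aromatic ring. The entering group carries a hydroxy on a saturated ring carbon where compound 1 carries an amino, which is the reverse of the change seen from compound 2 to compound 3. Compound 4 is therefore expected to give a higher number than compound 1, a 4.1-fold higher number from compound 1 to compound 4 (0.61 log units; beyond the scatter), and quite possibly only a limit. The estimate for compound 4 is 9000 nM, within a range from 3000 nM to 30000 nM.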

Compound 4, half-maximal inhibitory concentration: 5300 nM
The estimate for compound 4 lay 1.7-fold (0.23 log units) above the measured number; the measured number falls inside the stated range.
By their numbers in this assay, from the lowest: compound 3; then compound 1; then compound 4.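

In this assay, the new step is a 2.4-fold higher number from compound 1 to compound 4 (0.38 log units; beyond the scatter), and it has a measured number at both ends, so on this core the change from an amino-bearing to a hydroxy-bearing ether tail has a definite size and keeps the direction seen in the earlier pair, where the amino-bearing compound had the lower number. On these data alone, the earlier step, an at least 5.0-fold lower number from compound 2 to compound 3 (0.69 log units; beyond the scatter), could give only a minimum size, and its true size remains unknown: the limit of > 5000 nM in this assay, at which 1 of the 4 values shown sits. The new step is not a clean exchange of amino for hydroxy, however, since the 4-aminocyclohexyl, with one six-membered ring and two defined stereocentres, gives way to a group with two six-membered rings and no net change in donor or acceptor count, so the shift cannot be assigned to the hydroxy alone.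

The compounds shown leave open how much of the step belongs to the ring system and how much to the hydroxy, a question that a cyclohexyl carrying a hydroxy, or the two-ring group carrying an amino, on the core of compound 1 would address. They also leave open how a methylamino or a dimethylamino group at the same place would read in this assay.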